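The compounds below may be only part of what the source reports. "The series", "measured", "known", "first", "only" and "open" are said of these compounds alone.

Compound 1 `Cc1ccc(NS(=O)(=O)c2ccc(N3CCNC3=O)cc2)cc1` carries an aryl group on a sulfonamide nitrogen. In a functional assay on MCF7 cells (Homo sapiens) for antiproliferative activity, read by sulforhodamine B assay, with a stated time of 48 h (a higher number here means a weaker inhibitor, a lower number a stronger inhibitor), compound 1 gives 610 nM, the second highest of the three numbers measured. Compound 2 `O=C1NCCN1c1ccc(S(=O)(=O)Nc2ccc(F)c(F)c2)cc1` gives 620 nM, and the step of a 1.0-fold higher number from compound 1 to compound 2 (0.01 log units; within the scatter) lies within the scatter. Compound 3 `Cc1ccc(C)c(NS(=O)(=O)c2ccc(N3CCNC3=O)cc2)c1` gives 48 nM, and the step of a 13-fold lower number from compound 1 to compound 3 (1.10 log units; beyond the scatter) is large. Compound 4 `CCCCCCOc1ccc(NS(=O)(=O)c2ccc(N3CCNC3=O)cc2)cc1` differs from compound 1 by hexyloxy in place of methyl on an aromatic carbon. Neither step from compound 1 tests a long chain on that aromatic carbon: the change to 3,4-difluorophenyl left the number unchanged, while the gain in compound 3 came with 2,5-dimethylphenyl. The step is therefore expected to be small or none beyond the scatter, with wide uncertainty. Compound 4 is estimated at 500 nM, ranging from 150 nM to 2000 nM, an expected step of a 1.2-fold lower number from compound 1 to compound 4 (0.09 log units; within the scatter).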

Compound 4, half-maximal inhibitory concentration: > 1000 nM
Compound 4: a limit, no number; the forecaster's own chance of this, stated with the estimate: 5%; middle value at least 2.0-fold (0.30 log units) from the limit.
By their numbers in this assay, from the lowest: compound 3; then compounds 1 and 2 (each within the scatter of the next). At a limit, above all of these: compound 4.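

In this assay compound 4 gives > 1000 nM, which is a limit and not a number. Replacing methyl with hexyloxy on this aromatic carbon, para to a large group, brings no measurable gain, the first test of a long chain here: an at least 1.6-fold higher number from compound 1 to compound 4 (0.21 log units; that floor lies within the scatter). Since that floor lies within the scatter, how far the number rises cannot be read: the limit of > 1000 nM in this assay, at which 1 of the 4 values shown sits.

Still open, going by these compounds, is how shorter ethers such as methoxy or ethoxy, or an amine, would behave on this carbon. Also open, on these data alone, is whether a chain here would behave the same alongside the substitution pattern of compound 3.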